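Series notes: fluoro to chloro on the phenyl ring

This account rests on a few compounds, and the source may have more. Where it says the series, first, only, none or still open, it means among the compounds named here.

Measured so far:
compound 1 `CN1CCC(n2cc(S(=O)(=O)c3cccc(Cl)c3)c3cccnc32)C1`, 142 nM
compound 2 `CCN1CCC(n2cc(S(=O)(=O)c3cccc(F)c3)c3cccnc32)C1`, 132 nM

Both numbers come from a functional assay on HeLa cells for antagonist activity at 5-hydroxytryptamine receptor 6 (Homo sapiens), read by cAMP accumulation and immunoassay; a higher number here means a weaker inhibitor, a lower number a stronger inhibitor. Compound 2 has the lowest of the two numbers; its nearest neighbour is compound 1, whose number lies within the scatter, so no order between the two can be read.

Compound 3 `CCN1CCC(n2cc(S(=O)(=O)c3cccc(Cl)c3)c3cccnc32)C1` is not yet measured. It differs from compound 2 by chloro in place of fluoro on an aromatic carbon, in words chloro in place of fluoro on an aromatic carbon. Among the measured compounds shown here, no measured pair isolates this change, so the size of the step in this assay cannot be taken from the data. Compound 1 already carries the 3-chlorophenyl and sits within the scatter of compound 2, though it differs from both in another place. The expectation for compound 3 is a step of a 1.0-fold lower number from compound 2 to compound 3 (0.01 log units; within the scatter) that stays within the scatter, in no set direction. The estimate for compound 3 is 130 nM, with a range from 60 nM to 280 nM.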

Compound 3, half-maximal inhibitory concentration: 120 nM
The estimate for compound 3 lay 1.1-fold (0.03 log units) above the measured number; the range from low to high includes it.
By their numbers in this assay, from the lowest: compounds 3, 2 and 1 (each within the scatter of the next).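

In this assay the exchange of 3-fluorophenyl for 3-chlorophenyl now stands as an isolated pair, and a 1.1-fold lower number from compound 2 to compound 3 (0.04 log units; within the scatter) shows that chloro in place of fluoro at this place on the aromatic ring cannot be told apart from fluoro. The alkyl group on the ring amine nitrogen is isolated as well: methyl in place of hydrogen on the chain carbon bound to that nitrogen gives a 1.2-fold lower number from compound 1 to compound 3 (0.07 log units; within the scatter) and also stays within the scatter. Nothing available gives a cause for either result.

Going by these compounds, each exchange is seen only once, so how either would read on another background stays open. Also open, on these data alone, is how a methoxy group or a nitrile at this place on the aromatic ring, or a propyl chain on the amine nitrogen, would read.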